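Swapping the Outer Ring: What to Expect for Compound 4

This account rests on a few compounds, and the source may have more. Where it says the series, first, only, none or still open, it means among the compounds named here.

Three compounds share a common core and differ only in the group attached to one carbon of it. Compound 1 `CCNCc1cc(-c2c(C(=O)NCC)noc2-c2cc(C(C)C)c(O)cc2O)on1` gives 45 nM in a functional assay on HCT-116 cells (Homo sapiens) for inhibition; on this read-out lower numbers stand for stronger inhibition and higher numbers for weaker inhibition. Compound 2 `CCNC(=O)c1noc(-c2cc(C(C)C)c(O)cc2O)c1-c1cc(CN(C)C)no1` gives 92 nM in this assay, and compound 3 `CCNC(=O)c1noc(-c2cc(C(C)C)c(O)cc2O)c1-c1cc(C(=O)NC)no1` gives 124 nM. Compound 3 thus carries the highest number of the three: its gap to compound 2 lies within the scatter, while the step of a 2.8-fold higher number from compound 1 to compound 3 (0.44 log units; beyond the scatter) lies beyond it. Compound 4 `CCNC(=O)c1noc(-c2cc(C(C)C)c(O)cc2O)c1-c1cnn(CC)c1` is not yet measured. The change is 1-ethyl-1H-pyrazol-4-yl in place of 3-(methylcarbamoyl)-1,2-oxazol-5-yl on an aromatic carbon. All measured steps kept that outer ring and varied only the group on it: a 2.0-fold higher number from compound 1 to compound 2 (0.31 log units; beyond the scatter), a 2.8-fold higher number from compound 1 to compound 3 (0.44 log units; beyond the scatter) and a 1.3-fold higher number from compound 2 to compound 3 (0.13 log units; within the scatter), each modest or within the scatter. None exchanges the ring itself, so they bear only loosely on this step. The step of a 1.2-fold higher number from compound 3 to compound 4 (0.08 log units; within the scatter) is therefore expected to be small, with no firm direction. For compound 4 the estimated value is 150 nM, within a range from 50 nM to 450 nM.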

Compound 4, half-maximal inhibitory concentration: 26 nM
Compound 4: the middle estimate sits 5.8-fold (0.76 log units) above what was measured, and the stated range ends above it.
By their numbers in this assay, from the lowest: compounds 4 and 1 (each within the scatter of the next); then compounds 2 and 3 (each within the scatter of the next).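

The 3-substituted 1,2-oxazol-5-yl ring is not required at this position in this assay: exchanging it for 1-ethyl-1H-pyrazol-4-yl gives a 4.8-fold lower number from compound 3 to compound 4 (0.68 log units; beyond the scatter) and a 3.5-fold lower number from compound 2 to compound 4 (0.55 log units; beyond the scatter). The comparison with the ring bearing (ethylamino)methyl gives a 1.7-fold lower number from compound 1 to compound 4 (0.24 log units; within the scatter), so a ring carrying only an ethyl group stands level with it on this read-out. No available evidence explains why the new ring performs this way.

With a single pyrazole among the compounds shown, the part played by its ethyl group remains open: a methyl, a longer propyl chain or a chain ending in a dimethylamino group in its place could shift the number either way. As far as these compounds go, it is also open whether the (ethylamino)methyl or methylcarbamoyl groups would act on this ring as they do on the 1,2-oxazol-5-yl ring.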